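The compounds below may be only part of what the source reports. "The series", "measured", "known", "first", "only" and "open" are said of these compounds alone.

Compound 1 (`O=[N+]([O-])c1cc(C(F)(F)F)cc([N+](=O)[O-])c1Oc1ccc(Br)cc1/C=N\OCc1ccccc1`): 2240 nM
Compound 2 (`O=[N+]([O-])c1cc(C(F)(F)F)cc([N+](=O)[O-])c1Oc1ccc(Br)cc1/C=N\OCc1ccccc1F`): 1280 nM
Compound 3 (`O=[N+]([O-])c1cc(C(F)(F)F)cc([N+](=O)[O-])c1Oc1ccc(Br)cc1/C=N/OCc1ccccc1Cl`): not yet measured

In a functional assay on A549 cells (Homo sapiens) for antiproliferative activity, read by MTT assay, with a stated time of 48 h (on this read-out higher numbers stand for weaker inhibition and lower numbers for stronger inhibition), compound 2 gives 1280 nM and compound 1 gives 2240 nM. These two numbers are all that is known so far, and they lie within the scatter of each other, so compound 2 does not stand apart from compound 1.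

Compound 3 differs from compound 2 by a group of 11 heavy atoms (8 carbon, 1 nitrogen, 1 oxygen, 1 chlorine; one six-membered aromatic ring of carbon only) in place of a group of 11 heavy atoms (8 carbon, 1 nitrogen, 1 oxygen, 1 fluorine; one six-membered aromatic ring of carbon only), on an aromatic carbon. The change sits on an aromatic carbon of a six-membered aromatic ring of carbon only, ortho to a large group and meta to a bromo group.

Going by the values given here, one measured step bears on it, a 1.8-fold lower number from compound 1 to compound 2 (0.24 log units; within the scatter), which is fluoro in place of hydrogen on an aromatic carbon. Among the compounds with values here, no measured compound carries chlorine, so this small step is the only guide. No change beyond the scatter is therefore expected in this assay.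

The expected step is a 1.0-fold higher number from compound 2 to compound 3 (0.01 log units; within the scatter). For compound 3 the estimate is 1300 nM, with an expected range from 600 nM to 2800 nM.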

Compound 3, half-maximal inhibitory concentration: 3430 nM
Compound 3: the middle estimate sits 2.6-fold (0.42 log units) below what was measured, outside the stated range (above it).
By their numbers in this assay, from the lowest: compounds 2, 1 and 3 (each within the scatter of the next, the first and the last beyond it).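

In this assay, going by these compounds alone, this position now shows a response to the group placed there: the exchange gives a 2.7-fold higher number from compound 2 to compound 3 (0.43 log units; beyond the scatter), the first step to lie beyond the scatter, while the comparison with the hydrogen-bearing compound gives a 1.5-fold higher number from compound 1 to compound 3 (0.19 log units; within the scatter), which stays within it. The exchange is also more than a swap of fluorine for chlorine, since the structures show that the entering group has the opposite arrangement about its double bond, so this single step joins two structural differences. Nothing measured here accounts for the step.

The compounds shown leave open how much of the step belongs to the chlorine and how much to the arrangement about the double bond, as chlorine appears with one arrangement and fluorine and hydrogen with the other. They also leave open how this aromatic carbon would respond to a bromo group, a methoxy group, an amine or a carboxylic acid.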